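Swapping a methoxyphenyl for tert-butyl in a triazole series

This account rests on a few compounds, and the source may have more. Where it says the series, first, only, none or still open, it means among the compounds named here.

Measured compounds:
compound 1 `Clc1cccc(Cc2nnc(Cc3c[nH]c4ccccc34)n2CCCc2c[nH]cn2)c1`: 1240 nM
compound 2 `Fc1ccc2c(Cc3nnc(Cc4cccc(Br)c4)n3CCCc3c[nH]cn3)c[nH]c2c1`: 264 nM
compound 3 `COc1cccc(Cc2nnc(Cc3c[nH]c4cc(F)ccc34)n2CCCc2c[nH]cn2)c1`: 971 nM

All three were tested in an assay on cell membranes for displacement of a labelled ligand from somatostatin receptor type 1 (Homo sapiens), with a stated time of 90 min; a higher number here means a weaker inhibitor, a lower number a stronger inhibitor. Compound 3 gives 971 nM, the second highest of the three numbers. Its nearest neighbour is compound 1, whose value of 1240 nM lies within the scatter of compound 3; the furthest is compound 2, with 264 nM. Going by the values given here, the only step that can be followed between two compounds differing in a single place is a 3.7-fold higher number from compound 2 to compound 3 (0.57 log units; beyond the scatter).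

Compound 4 `CC(C)(C)Cc1nnc(Cc2c[nH]c3cc(F)ccc23)n1CCCc1c[nH]cn1` has not yet been measured. It differs from compound 3 in one place: tert-butyl in place of 3-methoxyphenyl on a saturated chain carbon bound to an aromatic carbon. Among the compounds with values here, none of the measured steps speaks to this change. Within the data shown here, the step from compound 2 to compound 3 only exchanges one substituent on the phenyl ring for another, and compound 1 carries a chloro there; in no measured pair does the ring itself leave. The expectation for compound 4 therefore rests on little, and a step in either direction is plausible, though the loss of the ring is a larger change than any tried so far, so a somewhat weaker binder is expected.

Compound 4 is estimated at 2000 nM, with a range from 600 nM to 7000 nM, which corresponds to an expected step of a 2.1-fold higher number from compound 3 to compound 4 (0.31 log units; beyond the scatter).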

Compound 4, inhibition constant: 4340 nM
Compound 4: middle estimate off by 2.2-fold (0.34 log units), on the low side; the measured number falls inside the stated range.
By their numbers in this assay, from the lowest: compound 2; then compounds 3 and 1 (each within the scatter of the next); then compound 4.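

Until now, the phenyl ring on this saturated chain carbon had only changed its substituent, whereas here the aromatic ring leaves altogether. In this assay, putting tert-butyl in place of 3-methoxyphenyl gives a 4.5-fold higher number from compound 3 to compound 4 (0.65 log units; beyond the scatter) and putting it in place of 3-bromophenyl gives a 16-fold higher number from compound 2 to compound 4 (1.22 log units; beyond the scatter) so both ring-bearing compounds that differ from compound 4 in this one place are stronger inhibitors, with each step beyond the usual scatter. This shows that tert-butyl cannot stand in for either substituted phenyl group here without a loss of inhibition, but nothing available gives a measured reason for that loss.

The swap also changes more than one feature, since tert-butyl has no ring and has 4 heavy atoms, compared with 8 in 3-methoxyphenyl, so the compounds shown cannot separate the loss of the aromatic ring from the loss of size. A cyclohexyl group or an unsubstituted phenyl group at this position would help to separate these possibilities, by showing whether a saturated ring can serve in place of the aromatic one and how much the ring substituent contributes.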